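Isopropyl to phenyl at the carbon bearing the amide nitrogen

This account rests on a few compounds, and the source may have more. Where it says the series, first, only, none or still open, it means among the compounds named here.

Measured compounds:
compound 1 `Cc1nc(N)sc1CCCN/C(N)=N/C(=O)NC(c1ccccc1)C(C)C`: 35.5 nM
compound 2 `Cc1nc(N)sc1CCCN/C(N)=N/C(=O)NC(C)c1ccccc1F`: 28.8 nM

The two measured compounds share the same core and differ only in the group attached to the amide-type nitrogen. In an assay on membranes from Sf9 cells for displacement of a labelled ligand from histamine H2 receptor (Homo sapiens), read by scintillation counting, with a stated time of 60 min (on this read-out lower numbers stand for stronger inhibition and higher numbers for weaker inhibition), compound 1 gives 35.5 nM, and in this assay compound 2 gives 28.8 nM. These two numbers lie within the usual scatter of each other, so compound 1 does not stand apart from compound 2 on the numbers shown, and nothing in the pair points in a direction.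

Compound 3 `Cc1nc(N)sc1CCCN/C(N)=N/C(=O)NC(c1ccccc1)c1ccccc1` has not yet been measured. It differs from compound 1 in one place: phenyl in place of isopropyl on a saturated chain carbon bound to an amide-type nitrogen and an aromatic carbon. Going by the values given here, no step between measured compounds of this kind is available, so the expectation rests only on the two numbers above, which give no hint of a trend. A change of this size at a carbon already carrying one aromatic ring is expected to move this assay only modestly, if at all, with a slight lean toward a lower number. The step from compound 1 to compound 3 is estimated as a 1.4-fold lower number from compound 1 to compound 3 (0.15 log units; within the scatter). Compound 3 is therefore expected to give about 25 nM, within a range from 8 nM to 80 nM.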

Compound 3, inhibition constant: 43.7 nM
Estimate against measurement, compound 3: 1.7-fold (0.24 log units) below; the range from low to high includes it.
By their numbers in this assay, from the lowest: compounds 2, 1 and 3 (each within the scatter of the next).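

In this assay, phenyl in place of isopropyl on a saturated chain carbon bound to an amide-type nitrogen and an aromatic carbon gives a 1.2-fold higher number from compound 1 to compound 3 (0.09 log units; within the scatter). This is the first step shown at this position, and it shows that this carbon can carry a second phenyl in place of the branched isopropyl without the number leaving the scatter, even though the entering group has a ring and 6 heavy atoms against 3 heavy atoms for the group that leaves. No evidence is available here that would explain this result.

What the compounds shown leave open is whether a group of a different kind at this carbon, such as an amine, a carboxylic acid or a longer chain, would move the number beyond the scatter, or whether this position tolerates those as well. They also leave open whether a hydroxyl or a methoxy group on one of the phenyl rings of compound 3 would shift the value in either direction.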